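Swapping Allyl for Phenyl on a Selenocyanate Carbamate

This account rests on a few compounds, and the source may have more. Where it says the series, first, only, none or still open, it means among the compounds named here.

Of the compounds shown here, three have so far been measured in a functional assay on MCF7 cells (Homo sapiens) for cytotoxicity, read by MTT assay, with a stated time of 72 h; on this read-out higher numbers stand for weaker inhibition of growth and lower numbers for stronger inhibition of growth. Compound 1 `CCOC(=O)Nc1ccc([Se][Se]c2ccc(NC(=O)OCC)cc2)cc1` gives 9900 nM. Compound 3 `O=C(Nc1ccc([Se][Se]c2ccc(NC(=O)Oc3ccccc3)cc2)cc1)Oc1ccccc1` gives 8000 nM. Compound 2 `C=CCOC(=O)Nc1ccc([Se]C#N)cc1` gives 15000 nM, which is the highest of the three numbers; the gap to compound 1 is the smallest and the gap to compound 3 the largest, yet both lie within the usual scatter of this assay, so the three compounds cannot really be told apart on these data.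

Compound 4 `N#C[Se]c1ccc(NC(=O)Oc2ccccc2)cc1` has not yet been measured. It differs from compound 2 in one place: phenyl in place of allyl on an oxygen next to a carbonyl group. For the measured compounds named here, no pair of measured compounds differs in exactly this way. The nearest comparison available is between compound 1 and compound 3, whose numbers sit within the scatter of one another. On that basis the step in this assay is expected to be small, in no clear direction, and a 1.3-fold lower number from compound 2 to compound 4 (0.10 log units; within the scatter) is the estimated change. Compound 4 is accordingly expected to give about 12000 nM in this assay, most likely between 5000 nM and 30000 nM.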

Compound 4, concentration for 50% growth inhibition: 4000 nM
Compound 4: the middle estimate sits 3.0-fold (0.48 log units) above what was measured; measured number below the stated range.
By their numbers in this assay, from the lowest: compounds 4, 3, 1 and 2 (each within the scatter of the next, the first and the last beyond it).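

In this assay, phenyl in place of allyl on an oxygen next to a carbonyl group gives a 3.8-fold lower number from compound 2 to compound 4 (0.57 log units; beyond the scatter). For the compounds shown here, this is the first comparison here between two compounds that differ in only one place, so the effect of this change can be read directly, without other differences in the structures getting in the way. It shows that the group on this oxygen matters: the step is modest, but it goes towards stronger inhibition of growth, although nothing available here explains why.

A single step cannot show whether the gain comes from the aromatic ring itself or simply from the loss of allyl. It also leaves open how a benzyl group, a longer chain such as hexyl, or a phenyl carrying a methoxy group would behave on the same oxygen.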